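Replacing Methoxyphenyl with Difluorophenyl on the Saturated Carbon

The source may report more compounds than this note shows. Statements on the series, on what has been measured and on what is new or still open speak of the compounds shown alone.

Compound 3 `COc1cccc(C2C(=O)N(C)c3cnc(Nc4ccc(S(N)(=O)=O)cc4)nc3N2C)c1` gives the highest number of the three compounds measured in an assay on Sf9 cells for inhibition of serine/threonine-protein kinase 4 (Homo sapiens), read by luminescence and ADP-Glo, with a stated time of 1 h, in the presence of a further agent that is not named here (on this read-out lower numbers stand for stronger inhibition and higher numbers for weaker inhibition), at 954 nM; compound 2 `CN1C(=O)C(c2ccccc2)N(C)c2nc(Nc3ccc(S(N)(=O)=O)cc3)ncc21` gives 383 nM and compound 1 `CN1C(=O)C(C2CC2)N(C)c2nc(Nc3ccc(S(N)(=O)=O)cc3)ncc21` gives 136 nM. The measured steps were a 2.8-fold higher number from compound 1 to compound 2 (0.45 log units; beyond the scatter), a 2.5-fold higher number from compound 2 to compound 3 (0.40 log units; beyond the scatter) and a 7.0-fold higher number from compound 1 to compound 3 (0.85 log units; beyond the scatter). Compound 4 `CN1C(=O)C(c2c(F)cccc2F)N(C)c2nc(Nc3ccc(S(N)(=O)=O)cc3)ncc21` differs from compound 3 by 2,6-difluorophenyl in place of 3-methoxyphenyl on a saturated ring carbon. No measured step covers fluorine on this aryl group; the one step that bears on the change, a 2.5-fold higher number from compound 2 to compound 3 (0.40 log units; beyond the scatter), suggests that removing the methoxy group brings the number back toward that of compound 2, while the two fluorines have no precedent among these compounds. Compound 4 is therefore expected to show a 3.0-fold lower number from compound 3 to compound 4 (0.47 log units; beyond the scatter), a modest move to a lower number. The estimate for compound 4 is 320 nM, within 90 nM to 1200 nM.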

Compound 4, half-maximal inhibitory concentration: 42 nM
The estimate for compound 4 lay 7.6-fold (0.88 log units) above the measured number, outside the stated range (below it).
By their numbers in this assay, from the lowest: compound 4; then compound 1; then compound 2; then compound 3.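

In this assay, an aryl group on this saturated ring carbon need not give a higher number than cyclopropyl: 2,6-difluorophenyl gives a 3.2-fold lower number from compound 1 to compound 4 (0.51 log units; beyond the scatter), although phenyl and 3-methoxyphenyl both stand above cyclopropyl. Adding the two fluorines to phenyl gives a 9.1-fold lower number from compound 2 to compound 4 (0.96 log units; beyond the scatter), and the change from the methoxy-bearing ring gives a 23-fold lower number from compound 3 to compound 4 (1.36 log units; beyond the scatter), the largest step in the set. Nothing available explains this gain. Still open, as far as these compounds go, is whether a single fluorine would be enough. It is also unknown whether chlorine or methyl in place of the two fluorines would give a similar number.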